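A few compounds are considered here, and "the series" means these few. Any claim that something is new, unique, unknown or untested is made for them only; others in the source may bear on it.

Of the compounds shown here, two built on a shared core have numbers so far in an in vitro ADME assay on microsomes from liver (Homo sapiens) for metabolic stability, tested at 1 mg/mL (on this read-out lower numbers stand for a shorter-lived compound and higher numbers for a longer-lived compound), and they sit close together. Compound 1 (`O=C(Nc1cc2cc[nH]c(=O)c2cc1Cl)C1CNCCC1c1ccccc1`) gives 0.617 h and compound 2 (`O=C(Nc1cc2cc[nH]c(=O)c2cc1Cl)[C@@H]1CCCNC1`) gives 1.18 h as its half-life. These two values lie within the usual scatter of each other, so compound 2 stands level with compound 1 and no order can be read from the pair. Compound 3 (`CN1CCC(C(=O)Nc2cc3cc[nH]c(=O)c3cc2Cl)CC1`) keeps the shared core but carries 1-methylpiperidin-4-yl in place of piperidin-3-yl on a carbonyl carbon. Going by the values given here, no measured pair isolates this change, so the data offer no direct guide to it. The expectation rests only on the agreement between compound 1 at 0.617 h and compound 2 at 1.18 h in this small set. In this assay no step beyond the scatter is expected, only a slight lean towards a shorter-lived compound, and the estimated move is a 1.3-fold lower number from compound 2 to compound 3 (0.12 log units; within the scatter) on this read-out. Compound 3 is estimated at 0.9 h with an expected range of 0.4 h to 2 h when measured.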

Compound 3, half-life: > 5 h
Compound 3: no number, only a limit (the forecaster's own chance of this, stated with the estimate: 5%); middle value at least 5.5-fold (0.74 log units) away from the limit.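

Going by these compounds alone, the swap on a carbonyl carbon whose other neighbour is an amide-type nitrogen is the first change in this small set to give a step beyond the scatter: 1-methylpiperidin-4-yl in place of piperidin-3-yl gives an at least 4.2-fold higher number from compound 2 to compound 3 (0.62 log units; beyond the scatter). So this position, where the earlier pair allowed no order, can carry a clear difference in half-life in this assay. The entry for compound 3 is a limit of the assay and not a number, so the step gives only its smallest size and its full size stays unknown: the limit of > 5 h in this assay, at which 1 of the 3 values shown sits.

The change also alters several things at once, since the group entering differs from the one leaving in where the ring is attached, in the methyl on its nitrogen, in its count of hydrogen-bond donors and in having no defined stereocentre, and the compounds shown do not tell which of these goes with the step. A plain piperidin-4-yl group or a 1-methylpiperidin-3-yl group would pull these apart, and a larger group on the ring nitrogen, such as an ethyl, would show whether the longer half-life holds beyond this one methyl compound.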